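Thiosemicarbazone series: aryl swap from compound 2 to compound 4

This account rests on a few compounds, and the source may have more. Where it says the series, first, only, none or still open, it means among the compounds named here.

Three compounds have been run in a functional assay on SGC-7901 cells (Homo sapiens) for antiproliferative activity, read by sulforhodamine B assay, with a stated time of 72 h; on this read-out higher numbers stand for weaker inhibition and lower numbers for stronger inhibition. Compound 1 `FC(F)(F)c1ccccc1NC(=S)N/N=C/c1ccc2ccccc2n1` gives 20700 nM in this assay. Compound 2 `Fc1ccccc1NC(=S)N/N=C/c1ccc2ccccc2n1` reaches only the limit of > 100000 nM in this assay, so no number is known for it. Compound 3 `NC(=S)N/N=C/c1nc2ccccc2s1` likewise sits at the limit of > 100000 nM in this assay. Among the measured compounds shown here, two of the three results therefore rest at the limit of > 100000 nM in this assay, at which 2 of the 3 values shown sit, and compound 2 stands at the weak end of what has been seen, with compound 1 the only member giving a number.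

For the measured compounds named here, the one measured step, an at least 4.8-fold higher number from compound 1 to compound 2 (0.68 log units; beyond the scatter), shows that the substituent on the aryl group moves the read-out beyond the scatter.

Going by the values given here, compound 4 `S=C(N/N=C/c1ccc2ccccc2n1)Nc1ccc(Br)cc1` is not yet measured. 4-bromophenyl in place of 2-fluorophenyl on an amide-type nitrogen No measured step covers this exact swap; the step from compound 1 to compound 2 is the only guide and shows that a change of this kind can be at least modest. A move back toward a measurable number is expected, with a real chance that the assay again reports only a limit. The expected step is an at least 2.5-fold lower number from compound 2 to compound 4 (0.39 log units; beyond the scatter), and compound 4 is estimated at 40000 nM with a range of 12000 nM to 130000 nM.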

Compound 4, half-maximal inhibitory concentration: 69400 nM
Beside the measured number, compound 4's estimate is 1.7-fold (0.24 log units) below it; low and high end bracket the measured number.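

At the amide-type nitrogen, 4-bromophenyl in place of 2-fluorophenyl brings a second number into this assay, so a result short of the limit is no longer confined to the trifluoromethyl-bearing compound 1. The swap amounts to an at least 1.4-fold lower number from compound 2 to compound 4 (0.15 log units; that floor lies within the scatter); compound 2 has only a limit and no number, so the true size of this change cannot be read. The assay limit still marks much of the series: the limit of > 100000 nM in this assay, at which 2 of the 4 values shown sit.

As far as these compounds go, whether the number follows the bromine or its place on the ring stays open, since this swap changes both together, and 4-fluorophenyl on the same nitrogen would separate the two. How an amine or a carboxylic acid in place of the bromine would read is open too.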